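Isopropyl to tert-butyl: notes on compound 3

The compounds below may be only part of what the source reports. "The series", "measured", "known", "first", "only" and "open" are said of these compounds alone.

Going by the values given here, in a functional assay on L1210 cells (Mus musculus) (on this read-out higher numbers stand for weaker inhibition and lower numbers for stronger inhibition), compound 1 (`CNC(=O)Nc1ccc(C(C)C)cc1`) gives 135000 nM, its only number, alongside one further entry without a single number. Compound 2 (`CCNC(=O)Nc1ccc(C(C)(C)C)cc1`), which also bears tert-butyl, has two widely separated entries, 16000 nM; 70 nM (2 entries), so it offers only a loose guide. Both lie lower than the value of compound 1.

Compound 3 (`CNC(=O)Nc1ccc(C(C)(C)C)cc1`) differs from compound 1 by one change, methyl in place of hydrogen on a saturated chain carbon bound to an aromatic carbon and two saturated chain carbons, or isopropyl to tert-butyl. Among the compounds with values here, no measured step isolates this change. A moderate move towards stronger inhibition in this assay is expected, beyond the scatter but with low confidence. The expected change is a 4.5-fold lower number from compound 1 to compound 3 (0.65 log units; beyond the scatter). For compound 3 the estimated value is 30000 nM, with an expected range of 5000 nM to 120000 nM.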

Compound 3, half-maximal inhibitory concentration: 80000 nM
Compound 3: the middle estimate sits 2.7-fold (0.43 log units) below what was measured; the range from low to high includes it.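

In this assay the change from isopropyl to tert-butyl now has a direct reading: it gives a 1.7-fold lower number from compound 1 to compound 3 (0.23 log units; within the scatter) and so does not separate the two groups at this saturated chain carbon. On this pair, methyl in place of hydrogen at that carbon leaves the number where it was, within the usual scatter. This is still one step on one pair, so it sets no trend for the position.

Open, from the compounds shown here alone, is how a longer chain such as n-butyl, or a carboxylic acid, would read at this place on the core of compound 1. Compound 3 and compound 2 differ in one place, yet the effect of that difference cannot be read firmly from them: the several entries of compound 2 in this assay, 16000 nM; 70 nM (2 entries)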